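The compounds below may be only part of what the source reports. "The series", "measured", "known", "first", "only" and "open" are said of these compounds alone.

Compound 1 `COc1ccccc1-c1ccc(CNC(=O)NC2CCN(Cc3ccc(C)cc3)CC2)cc1` and compound 2 `Cc1ccc(CN2CCC(NC(=O)NCc3ccc(-c4cccc(C#N)c4)cc3)CC2)cc1` share one core and differ in a single aromatic substituent. In an in vitro functional assay on HEK293 cells for antagonist activity at melanin-concentrating hormone receptor 1 (Homo sapiens), read by GTPgammaS binding, with a stated time of 45 min (a higher number here means a weaker inhibitor, a lower number a stronger inhibitor), compound 1 gives 642 nM. In this assay, among the compounds with values here, compound 2 gives 411 nM, the lowest of the two numbers so far, with compound 1 as its nearest neighbour. Within the data shown here, the only measured step, a 1.6-fold lower number from compound 1 to compound 2 (0.19 log units; within the scatter), is the one step that bears on the next change. Compound 3 `Cc1ccc(CN2CCC(NC(=O)NCc3ccc(-c4ccccc4)cc3)CC2)cc1` is not yet measured; it differs from compound 2 by hydrogen in place of cyano on an aromatic carbon. Among the measured compounds shown here, since the one comparable step, a 1.6-fold lower number from compound 1 to compound 2 (0.19 log units; within the scatter), also exchanged the substituent on that ring and stayed within the scatter, no change beyond the scatter is expected here either. The expected step is a 1.2-fold higher number from compound 2 to compound 3 (0.09 log units; within the scatter), none beyond the scatter. On that basis compound 3 is estimated at 500 nM in this assay, with a range from 200 nM to 1300 nM.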

Compound 3, antagonist equilibrium constant: 1060 nM
Compound 3: middle estimate off by 2.1-fold (0.33 log units), on the low side, within the range that was stated.
By their numbers in this assay, from the lowest: compounds 2, 1 and 3 (each within the scatter of the next, the first and the last beyond it).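

In this assay, within the data shown here, the nitrile on this aromatic carbon now separates from bare hydrogen: hydrogen in place of cyano gives a 2.6-fold higher number from compound 2 to compound 3 (0.41 log units; beyond the scatter) and is the first step to lie beyond the scatter. Hydrogen in place of methoxy gives a 1.7-fold higher number from compound 1 to compound 3 (0.22 log units; within the scatter) and stays within the scatter, so 3-cyanophenyl can be told from phenyl in this series, while 2-methoxyphenyl cannot. No measurement at hand accounts for the difference between these two steps.

As far as these compounds go, whether an amine or a carboxylic acid at this ring position would give a number nearer compound 2 or compound 3 remains open. Also open, from the compounds shown here alone, is whether the step from the nitrile holds with the methyl group on the far benzyl ring replaced by a chlorine atom.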